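A few compounds are considered here, and "the series" means these few. Any claim that something is new, unique, unknown or untested is made for them only; others in the source may bear on it.

Measured in an ADME assay on GES1 cells (Homo sapiens) for inhibition, read by MTT assay, with a stated time of 72 h; on this read-out lower numbers stand for stronger inhibition and higher numbers for weaker inhibition:

Compound 1 `Cc1cc(Nc2cc(-c3cccs3)[nH]n2)n2nc(SCc3ccc(Br)cc3)nc2n1`: 38700 nM
Compound 2 `CCCCCc1c(C)nc2nc(SCc3ccc(Cl)cc3)nn2c1Nc1cc(-c2ccccc2)[nH]n1`: > 50000 nM (a limit of the assay, not a number)
Compound 3 `Cc1cc(Nc2cc(-c3ccccc3)[nH]n2)n2nc(SCC(=O)c3ccccc3)nc2n1`: 33300 nM

Compound 3, at 33300 nM, lies within the usual scatter of compound 1 at 38700 nM. These two compounds differ in more than one place, yet their values cannot be told apart.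

Compound 4 `Cc1cc(Nc2cc(-c3ccccc3)[nH]n2)n2nc(SCc3nc4ccccc4[nH]3)nc2n1` has 1H-benzimidazol-2-yl in place of benzoyl on a saturated chain carbon bound to a sulfur. For the measured compounds named here, no measured pair isolates this change, so the expectation rests on the closeness of compound 1 and compound 3. Only a change inside the usual scatter, in no particular direction, is expected: a 1.1-fold higher number from compound 3 to compound 4 (0.02 log units; within the scatter). For compound 4 the estimated value is 35000 nM, with an expected range of 15000 nM to 60000 nM.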

Compound 4, half-maximal inhibitory concentration: 27800 nM
Estimate against measurement, compound 4: 1.3-fold (0.10 log units) above; measured number inside the range.
By their numbers in this assay, from the lowest: compounds 4, 3 and 1 (each within the scatter of the next). At a limit, above all of these: compound 2.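

In this assay the first pair differing in one place gives a 1.2-fold lower number from compound 3 to compound 4 (0.08 log units; within the scatter) for this swap, so the two values cannot be told apart. At this place on a saturated chain carbon bound to a sulfur, benzoyl and 1H-benzimidazol-2-yl are thus interchangeable in this read-out, although the latter adds a five-membered aromatic ring and a hydrogen-bond donor. Nothing shown here accounts for this closeness.

On these data alone, whether a simple amine or a carboxylic acid at this place would give a clearly different number remains open.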